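From 4-bromo-2-fluorobenzyl to 4-fluorobenzyl in compound 1

The source may report more compounds than this note shows. Statements on the series, on what has been measured and on what is new or still open speak of the compounds shown alone.

Compound 1 `O=C(O)CN1C(=O)/C(=C/c2nc3ccccc3n2Cc2ccc(Br)cc2F)SC1=S`: 28400 nM
Compound 2 `N#Cc1ccc(Cn2c(/C=C3\SC(=S)N(CC(=O)O)C3=O)nc3ccccc32)cc1`: 11200 nM
Compound 3 `O=C(O)CN1C(=O)/C(=C/c2nc3ccccc3n2Cc2ccc([N+](=O)[O-])cc2)SC1=S`: 7760 nM
Compound 4 `O=C(O)CN1C(=O)/C(=C/c2nc3ccccc3n2Cc2ccc(F)cc2)SC1=S`: not yet measured

In a functional assay on MDA-MB-231 cells (Homo sapiens) for cytotoxicity, read by MTT assay, with a stated time of 48 h (on this read-out higher numbers stand for weaker inhibition and lower numbers for stronger inhibition), compound 1 stands highest of the three measured compounds, at 28400 nM. Compound 4 replaces its 4-bromo-2-fluorophenyl with 4-fluorophenyl, on a saturated chain carbon bound to an aromatic nitrogen: 4-fluorophenyl in place of 4-bromo-2-fluorophenyl on a saturated chain carbon bound to an aromatic nitrogen. Two replacements at the same place bear on this: a 2.5-fold lower number from compound 1 to compound 2 (0.40 log units; beyond the scatter) and a 3.7-fold lower number from compound 1 to compound 3 (0.56 log units; beyond the scatter). Both are modest, while a 1.4-fold lower number from compound 2 to compound 3 (0.16 log units; within the scatter) stays within the scatter. Among the compounds with values here, neither entering group is the one in compound 4, so they suggest only a direction and a rough size. A modest move to a lower number is therefore expected, with the expected step of a 2.0-fold lower number from compound 1 to compound 4 (0.31 log units; beyond the scatter). Compound 4 is estimated at 14000 nM, with an expected range of 6500 nM to 30000 nM.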

Compound 4, half-maximal inhibitory concentration: 2620 nM
For compound 4 the middle estimate is 5.3-fold (0.73 log units) above the measured one; the whole stated range lies above it.
By their numbers in this assay, from the lowest: compound 4; then compounds 3 and 2 (each within the scatter of the next); then compound 1.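

With an 11-fold lower number from compound 1 to compound 4 (1.04 log units; beyond the scatter) as its step in this assay, 4-fluorophenyl moves the number further than either earlier replacement at this place, and compound 4 stands lowest of the four. The nitro and cyano groups had stayed within the scatter of each other, yet fluoro separates from both, with a 3.0-fold lower number from compound 3 to compound 4 (0.47 log units; beyond the scatter) and with a 4.3-fold lower number from compound 2 to compound 4 (0.63 log units; beyond the scatter) as well. No measurement at hand accounts for these steps.

The compounds shown do not separate losing the bromine from losing the second fluorine, as both go in one step. On these data alone, whether a chloro or methoxy group on that aromatic carbon would match fluoro remains open.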